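Dropping One Methoxy Group: What to Expect for Compound 4

The compounds below may be only part of what the source reports. "The series", "measured", "known", "first", "only" and "open" are said of these compounds alone.

Three compounds have been measured in an assay on cells for inhibition of Amine oxidase [flavin-containing] B (Homo sapiens), read by fluorescence, with stated times of 10 min and 20 min, tested at 25 uM; a higher number here means more inhibition at the concentration tested (going by the name of the read-out), a lower number less inhibition:

compound 1, `COc1c(C)c(C/C=C(\C)CCC=C(C)C)c(OC)c(OC)c1OC`, gives 38%
compound 2, `COc1c(C)c(C/C=C(\C)CC/C=C(\C)CCC=C(C)C)c(OC)c(OC)c1OC`, gives 15.2%
compound 3, `COc1c(C)c(CC=C(C)C)c(OC)c(OC)c1OC`, gives 7.2%

Compound 3 stands lowest of the three numbers. One step, a number 8 percentage points lower from compound 2 to compound 3 (within the scatter), lies within the scatter, so those two cannot be told apart, whereas another step, a number 30.8 percentage points lower from compound 1 to compound 3 (beyond the scatter), lies beyond it. The remaining step, a number 22.8 percentage points lower from compound 1 to compound 2 (beyond the scatter), likewise concerns the chain attached to the shared core.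

Compound 4, `COc1cc(C)c(CC=C(C)C)c(OC)c1OC`, differs from compound 3 in a single place: hydrogen in place of methoxy on an aromatic carbon. Every measured step alters the chain on a saturated chain carbon bound to a double-bonded chain carbon; none alters a methoxy group on the aromatic ring. Among the compounds with values here, no measured step therefore bears on this change, and there is no ground for expecting a shift in either direction. The step expected in this assay is a number 0.8 percentage points higher from compound 3 to compound 4 (within the scatter), within the scatter. Compound 4 is expected to give 8%, with a range from 0% to 22%.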

Compound 4, a percentage reported as inhibition, at one concentration (the size of the read-out at that concentration, not a potency): 18.6%
For compound 4 the middle estimate is 10.6 percentage points below the measured one; the range from low to high includes it.
By their numbers in this assay, from the lowest: compounds 3, 2 and 4 (each within the scatter of the next, the first and the last beyond it); then compound 1.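

In this assay, within the data shown here, replacing one methoxy group with hydrogen on the aromatic carbon ortho to a methyl group gives a number 11.4 percentage points higher from compound 3 to compound 4 (beyond the scatter) and is the first step here beyond the scatter that involves the ring rather than the chain. So this read-out responds to a substituent on the ring as well, and this methoxy group is not needed for the inhibition seen with compound 3. Nothing available explains why removing it gives a higher number.

Still open, from the compounds shown here alone, is whether the same change would give a similar step on the 3,7-dimethylocta-2,6-dien-1-yl chain, or whether the other methoxy groups behave like this one. Also unknown is how a hydroxyl, an amine or a fluorine at this carbon would compare with hydrogen.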